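The source may report more compounds than this note shows. Statements on the series, on what has been measured and on what is new or still open speak of the compounds shown alone.

Series of macrocyclic polyether esters tested in a functional assay on HBL-100 cells (Homo sapiens) for inhibition, read by sulforhodamine B assay, with a stated time of 48 h; on this read-out higher numbers stand for weaker inhibition of growth and lower numbers for stronger inhibition of growth. Compound 2 `CC(C)=CC1C(C(=O)OCC2COCCOCCOCCOCCOCCO2)C1(C)C` gives 40000 nM in this assay. Compound 3 `O=C(CCCCCCCCCCOc1ccccc1)OCC1COCCOCCOCCOCCOCCO1` gives 20000 nM in this assay; the gap to compound 2 is within the scatter, so the two cannot be ranked. Compound 1 `O=C(CCCCOc1ccccc1)OCC1COCCOCCOCCOCCOCCO1` reaches only a limit, > 100000 nM, in this assay (the limit of > 100000 nM in this assay, at which 1 of the 3 values shown sits). Among the compounds with values here, the single measured step, an at least 2.5-fold lower number from compound 1 to compound 2 (0.39 log units; beyond the scatter), shows that the acyl group matters. Compound 4 `O=C(CCCCC1CCCCC1)OCC1COCCOCCOCCOCCOCCO1` carries the change (4-cyclohexylbutyl in place of 2,2-dimethyl-3-(2-methylprop-1-en-1-yl)cyclopropyl on a carbonyl carbon). As the entering chain resembles the acyl groups of compound 1 and compound 3 rather than that of compound 2, a step back toward the chain-bearing esters is expected, a 1.1-fold lower number from compound 2 to compound 4 (0.06 log units; within the scatter). Compound 4 is estimated at 35000 nM in this assay, between 12000 nM and 100000 nM.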

Compound 4, concentration for 50% growth inhibition: 72000 nM
Compound 4: the middle estimate sits 2.1-fold (0.31 log units) below what was measured, and the stated range covers the measured number.
By their numbers in this assay, from the lowest: compounds 3, 2 and 4 (each within the scatter of the next, the first and the last beyond it). At a limit, above all of these: compound 1.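

In this assay, 4-cyclohexylbutyl in place of 2,2-dimethyl-3-(2-methylprop-1-en-1-yl)cyclopropyl on a carbonyl carbon gives a 1.8-fold higher number from compound 2 to compound 4 (0.26 log units; within the scatter), so a saturated ring on a chain and the cyclopropyl group cannot be ranked at this position. Cyclohexyl in place of phenoxy gives an at least 1.3-fold lower number from compound 1 to compound 4 (0.14 log units; that floor lies within the scatter), so this change has no readable direction. The value of compound 1 is a limit, so the step has only a floor: the limit of > 100000 nM in this assay, at which 1 of the 4 values shown sits.

Still open, going by these compounds, is whether a longer chain ending in cyclohexyl would separate from these values. On these data alone, the effect of an amine or a carboxylic acid on the chain is also open.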